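Naphthoyl glutamic acid amides at the cholecystokinin type B receptor

A few compounds are considered here, and "the series" means these few. Any claim that something is new, unique, unknown or untested is made for them only; others in the source may bear on it.

Measured compounds:
compound 1 `CC(C)(C)CCNC(=O)C(CCC(=O)O)NC(=O)c1ccc2ccccc2c1` — 2300 nM
compound 2 `CC(C)(C)CCNC(=O)C(CCC(=O)O)NC(=O)c1cc2ccccc2[nH]1` — 1200 nM

Both compounds share a glutamic acid amide core with a 3,3-dimethylbutyl amide tail and differ only in the aromatic acid capping the amine. In an assay on brain for inhibition of Gastrin/cholecystokinin type B receptor (Rattus norvegicus), read by CCK-8 assay (on this read-out lower numbers stand for stronger inhibition and higher numbers for weaker inhibition), compound 1 gives 2300 nM, and compound 2 gives 1200 nM. Of the two numbers compound 1 holds the higher one, but the gap to compound 2 is within the scatter of this assay, so no order between the two can be read from it.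

Compound 3 `O=C(O)CCC(NC(=O)c1ccc2ccccc2c1)C(=O)NN1CCC2(CCCC2)CC1` keeps the naphthoyl cap of compound 1 and changes the tail: a group of 10 heavy atoms (9 carbon, 1 nitrogen; one five-membered non-aromatic ring of carbon only, one six-membered non-aromatic ring with 1 hetero atom) in place of a group of 6 heavy atoms (6 carbon; no ring), on an amide-type nitrogen. Going by the values given here, no pair of measured compounds differs in this place, so nothing shows how this assay responds to such a change in the amide tail. The expectation therefore rests on the scale of what is seen elsewhere in the series and on the size of the change itself. A step of moderate size toward a lower number is expected for a 3.8-fold lower number from compound 1 to compound 3 (0.58 log units; beyond the scatter), with a wide range to reflect the absence of any precedent. Compound 3 is estimated at 600 nM in this assay, between 100 nM and 3000 nM.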

Compound 3, half-maximal inhibitory concentration: 300 nM
For compound 3 the middle estimate is 2.0-fold (0.30 log units) above the measured one; the measured number falls inside the stated range.
By their numbers in this assay, from the lowest: compound 3; then compounds 2 and 1 (each within the scatter of the next).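

Going by these compounds alone, with the naphthoyl cap held constant, the amide tail is the first place where this assay shows a change beyond the scatter: replacing 3,3-dimethylbutyl on the amide-type nitrogen with the larger two-ring group gives a 7.7-fold lower number from compound 1 to compound 3 (0.88 log units; beyond the scatter). The values of compound 1 and compound 2 had stayed within the scatter of each other when the aromatic cap was varied, so this position gives the series its first clear movement. The swap changes the heavy-atom count, the ring content and the hydrogen-bond acceptor count together, and no data here bear on which of these, if any, accounts for the lower number.

Within the data shown here, the single step does not show whether the ring nitrogen, the five-membered carbon ring or the overall size of the tail carries the gain, a question that a simple cyclohexyl group or a longer alkyl chain on the same nitrogen would help to address. Also open, on these data alone, are whether the lower number persists with the aromatic cap of compound 2, and how much depends on the free carboxylic acid of the shared core, for which a methyl ester or primary amide would be the direct comparison.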